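Swapping the ortho group: methylsulfanyl gives way to phenyl

This account rests on a few compounds, and the source may have more. Where it says the series, first, only, none or still open, it means among the compounds named here.

Compound 2 `CSc1ccccc1NC(=S)N1CCc2c(sc(NC(=O)c3ccccc3Cl)c2C(N)=O)C1` gives 14600 nM in a functional assay on HL-60 cells (Homo sapiens) for antiproliferative activity, with a stated time of 24 h (a higher number here means a weaker inhibitor, a lower number a stronger inhibitor), the higher of the two numbers seen so far. Within the data shown here, compound 1 `NC(=O)c1c(NC(=O)c2ccccc2Cl)sc2c1CCN(C(=S)Nc1ccccc1I)C2` gives 4430 nM, and the step of a 3.3-fold higher number from compound 1 to compound 2 (0.52 log units; beyond the scatter) is the only comparison available at this position. Compound 3 `NC(=O)c1c(NC(=O)c2ccccc2Cl)sc2c1CCN(C(=S)Nc1ccccc1-c1ccccc1)C2` carries the change (phenyl in place of methylsulfanyl on an aromatic carbon). Among the measured compounds shown here, since the one measured step shows that swapping this group shifts the number by a modest amount, a step of similar size is expected here, with the direction uncertain but leaning downward. Compound 3 is therefore expected to give 6000 nM, within 2000 nM to 25000 nM, corresponding to an estimated step of a 2.4-fold lower number from compound 2 to compound 3 (0.39 log units; beyond the scatter).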

Compound 3, half-maximal inhibitory concentration: 34400 nM
Compound 3: middle estimate off by 5.7-fold (0.76 log units), on the low side, and the stated range ends below it.
By their numbers in this assay, from the lowest: compound 1; then compound 2; then compound 3.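

In this assay, phenyl takes the number further up than methylsulfanyl did, with a 2.4-fold higher number from compound 2 to compound 3 (0.37 log units; beyond the scatter) and a 7.8-fold higher number from compound 1 to compound 3 (0.89 log units; beyond the scatter). Both replacements of iodo so far raise the number, and among these three groups iodo gives the lowest number and phenyl the highest. Nothing measured here explains this order.

Still open, as far as these compounds go, is how a methoxy group, an amine or a carboxylic acid at this position would compare with iodo. From the compounds shown here alone, whether any group can bring the number below that of compound 1 also remains unknown.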